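Bromo in Place of Methyl: One Atom Swapped

The source may hold more compounds than are shown below. What is called first, only, known or untested is meant among the compounds shown, and "the series" means these compounds.

Measured compounds:
compound 1, `CCOc1ccc(NC(=O)Nc2cc(C(C)(C)C)nn2-c2ccccc2)cc1`: 1.1 degrees C
compound 2, `Cc1ccc(-n2nc(C(C)(C)C)cc2NC(=O)Nc2cc(F)cc(F)c2)cc1`: 2.8 degrees C

Both compounds were tested in an assay on isolated protein for inhibition of STE20-like serine/threonine-protein kinase (Homo sapiens), read by thermal shift assay, tested at 10 uM; a lower number here means that the compound stabilises the target less, a higher number that the compound stabilises the target more against heat. Of the two numbers, compound 2 has the higher one; the nearest is compound 1, whose value lies lower by a gap beyond the usual scatter of this measurement. So compound 2 is the better stabiliser of the two shown here, and no other comparison is available.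

Compound 3, `CC(C)(C)c1cc(NC(=O)Nc2cc(F)cc(F)c2)n(-c2ccc(Br)cc2)n1`, has not yet been measured. It differs from compound 2 in a single place: bromo in place of methyl on an aromatic carbon. Within the data shown here, no measured pair in this set shares that difference, so there is nothing to lean on for its size or direction. Where a single atom is replaced by another of similar size and with no change in donors, acceptors or charge, the expectation is a step in this assay of no more than the scatter, in either direction. The step from compound 2 to compound 3 is therefore expected to be about no change at the digits printed from compound 2 to compound 3 (within the scatter). For compound 3 the estimated result is 2.8 degrees C, with a range from 1.3 degrees C to 4.3 degrees C.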

Compound 3, shift of the target's melting temperature: 0.5 degrees C
Beside the measured number, compound 3's estimate is 2.3 degrees C above it; the whole stated range lies above it.
By their numbers in this assay, from the lowest: compounds 3 and 1 (each within the scatter of the next); then compound 2.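

In this assay, replacing methyl with bromo on an aromatic carbon, para to a large group, gives a number 2.3 degrees C lower from compound 2 to compound 3 (beyond the scatter). Among these compounds, this is the first sign that this position is sensitive to what sits on it: one heavy atom replaces another, the counts of hydrogen-bond donors and acceptors stay the same, no net charge appears, and the read-out still moves by more than the usual scatter. Of the two groups seen here, the 4-methylphenyl form therefore stabilises the target more than the 4-bromophenyl form, but nothing among the available data explains why the single-atom swap has this effect.

This single pair gives the direction of one change on one background, so it cannot show whether the same swap would lower the read-out on a different core or with a different group on the other side of the shared core. It also leaves open where groups such as chloro, ethyl, methoxy or an amine at the same position would fall relative to methyl and bromo.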